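Swapping chloro for isopropyl on the shared core

The source may report more compounds than this note shows. Statements on the series, on what has been measured and on what is new or still open speak of the compounds shown alone.

Measured compounds:
compound 1, `Clc1ccc(NC2=NCCC3(CCCCC3)S2)cc1`, 2.5
compound 2, `FC(F)(F)c1ccc(NC2=NCCC3(CCCCC3)S2)cc1`, 2.18

Two compounds have been run in a physicochemical assay for lipophilicity, measured as octanol-water partition, at pH 7.4; a lower number here means a more polar compound, a higher number a more lipophilic compound. Compound 1 gives 2.5, the higher of the two numbers, and its nearest neighbour is compound 2 with 2.18. Going by the values given here, the single measured step, a number 0.32 log units lower from compound 1 to compound 2 (beyond the scatter), goes with trifluoromethyl in place of chloro on an aromatic carbon.

The unmeasured compound 3, `CC(C)c1ccc(NC2=NCCC3(CCCCC3)S2)cc1`, differs from compound 1 in one place: isopropyl in place of chloro on an aromatic carbon. Among the compounds with values here, the step from compound 1 to compound 2 concerns a different incoming group, so no measured step bears directly on this change; it shows only that a single swap at this aromatic carbon can move the value by a modest amount in this assay. Since isopropyl brings in three carbon atoms where chloro brought one chlorine, the value for compound 3 is expected to rise, giving an estimated step of a number 0.40 log units higher from compound 1 to compound 3 (beyond the scatter). Compound 3 is therefore estimated at 2.9, with a likely range from 2.4 to 3.4.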

Compound 3, distribution coefficient: 1.57
The estimate for compound 3 lay 1.33 log units above the measured number; measured number outside the range, below it.
By their numbers in this assay, from the lowest: compound 3; then compound 2; then compound 1.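

In this assay, going by these compounds alone, this aromatic carbon proves more sensitive to the choice of group than the first pair of compounds could show: isopropyl in place of chloro gives a number 0.93 log units lower from compound 1 to compound 3 (beyond the scatter), a larger move than the one seen with trifluoromethyl. The direction also holds against the other halogen-bearing group, with a number 0.61 log units lower from compound 2 to compound 3 (beyond the scatter), so the three groups at this carbon now stand apart, and isopropyl, the only one without a halogen, gives the lowest number. A larger group made of carbon atoms therefore did not bring a higher number here, and nothing available explains why this step runs downward.

What remains open is whether the low number belongs to isopropyl alone or also appears with other carbon groups, such as methyl or tert-butyl, and where a methoxy group or an amine at the same carbon would fall among these three compounds. Three compounds on one shared core also cannot show whether the same swaps would move the number in the same direction on a different core.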